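This account rests on a few compounds, and the source may have more. Where it says the series, first, only, none or still open, it means among the compounds named here.

Measured compounds:
compound 1, `O=C(CCl)Nc1ccc(I)cc1`, 9700 nM
compound 2, `O=C(CCCl)Nc1ccc(I)cc1`, 18000 nM
compound 3, `CC(C)(C)c1ccc(CNC(=O)CCCl)cc1`, 87000 nM

All three were tested in a functional assay on HT-29 cells (Homo sapiens) for antiproliferative activity, with a stated time of 48 h; on this read-out higher numbers stand for weaker inhibition and lower numbers for stronger inhibition. Compound 1 and compound 2 share one core, and compound 2 carries chloromethyl in place of chloro on a saturated chain carbon bound to a carbonyl carbon. The step of a 1.9-fold higher number from compound 1 to compound 2 (0.27 log units; within the scatter) is small, so the two values of compound 1 and compound 2 cannot be told apart here. Compound 3 has a different core, and the difference between the two cores is not broken down here. In this assay compound 3 gives 87000 nM, the highest of the three numbers, and its gaps to compound 2 and to compound 1 both lie beyond the scatter.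

Compound 4, `CC(C)(C)c1ccc(CNC(=O)CCCCl)cc1`, has not been measured. It carries chloromethyl in place of chloro on a saturated chain carbon, two bonds along the chain from a carbonyl carbon. Within the data shown here, this is the same kind of change as the one from compound 1 to compound 2, but not the same: there the new group sat on a saturated chain carbon bound to a carbonyl carbon, whereas here it sits on a saturated chain carbon, two bonds along the chain from a carbonyl carbon, and the core is different as well. Among the measured compounds shown here, the one measured example of this kind of change, a 1.9-fold higher number from compound 1 to compound 2 (0.27 log units; within the scatter), stayed within the scatter, so for compound 4 a step of about a 1.7-fold higher number from compound 3 to compound 4 (0.24 log units; within the scatter) is expected, also within the scatter, with wide uncertainty because of the change of core and of place. On this basis compound 4 is estimated at 150000 nM in this assay, between 60000 nM and 400000 nM.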

Compound 4, half-maximal inhibitory concentration: 72000 nM
For compound 4 the middle estimate is 2.1-fold (0.32 log units) above the measured one, within the range that was stated.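

Adding one carbon to the chlorine-bearing chain on the second core gives a small step in this assay (a 1.2-fold lower number from compound 3 to compound 4 (0.08 log units; within the scatter)), and the values of these two compounds cannot be told apart. Set beside the same kind of change on the first core, this step shows no measurable difference between the two cores: the same change on two cores in this assay, a 1.9-fold higher number (0.27 log units; within the scatter) from compound 1 to compound 2 and a 1.2-fold lower number (0.08 log units; within the scatter) from compound 3 to compound 4, 2.2-fold (0.35 log units) apart, within the scatter of two such steps

This means that, for these two pairs, the change from chloro to chloromethyl carried over from one core to the other without a step beyond the usual scatter. Among these compounds, it does not show that the chain length is without effect in general, since there is only one pair on each core, the change sits at a different place on the chain in each pair, and small real differences could be hidden within the scatter.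

The compounds shown leave open what a longer chain than 3-chloropropyl would do in this assay, on either core. They also leave open whether the chlorine itself is needed for the antiproliferative activity, which could be tested by putting a hydroxyl group or an amine in its place at the end of the chain.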